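A few compounds are considered here, and "the series" means these few. Any claim that something is new, unique, unknown or untested is made for them only; others in the source may bear on it.

Working notes on the series. Of the compounds shown here, two have been measured in an ADME assay on Vero cells (Chlorocebus sabaeus) for cytotoxicity; on this read-out higher numbers stand for weaker inhibition and lower numbers for stronger inhibition. Compound 1 `O=C1Nc2ccc([N+](=O)[O-])cc2/C1=N/NC(=S)NC1CCCCC1` gives 4.74 ug/mL. Compound 2 `Cc1ccc(NC(=S)N/N=C2\C(=O)Nc3ccc([N+](=O)[O-])cc32)cc1` gives 2.45 ug/mL. Going by the values given here, the only step between measured compounds is a 1.9-fold lower number from compound 1 to compound 2 (0.29 log units; within the scatter), so on the numbers in hand compound 2 and compound 1 lie within the scatter of each other and neither can be called apart from the other in this assay.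

Compound 3 `O=C1Nc2ccc([N+](=O)[O-])cc2/C1=N/NC(=S)Nc1ccc(Br)cc1` has not been measured. Against compound 2 the change is bromo in place of methyl on an aromatic carbon. Among the compounds with values here, no measured step touches this ring position; the single measured step, a 1.9-fold lower number from compound 1 to compound 2 (0.29 log units; within the scatter), exchanged the whole group on the amide-type nitrogen and itself stayed within the scatter. Within the data shown here, with that as the only guide, and no change in donors, acceptors or charge, no step beyond the scatter is expected here either: the number for compound 3 in this assay is estimated at 2.5 ug/mL, range 1 ug/mL to 6 ug/mL. The expected step, a 1.0-fold higher number from compound 2 to compound 3 (0.01 log units; within the scatter), is therefore close to none.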

Compound 3, half-maximal inhibitory concentration: 2.59 ug/mL
Beside the measured number, compound 3's estimate is 1.0-fold (0.02 log units) below it, and the stated range covers the measured number.
By their numbers in this assay, from the lowest: compounds 2, 3 and 1 (each within the scatter of the next).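

This ring position now has its first measured step: in this assay, bromo in place of methyl on the aromatic carbon para to a large group gives a 1.1-fold higher number from compound 2 to compound 3 (0.02 log units; within the scatter), so 4-methylphenyl and 4-bromophenyl cannot be told apart on this read-out. The second aryl group also stays close to the cyclohexyl compound, with 4-bromophenyl in place of cyclohexyl on the amide-type nitrogen giving a 1.8-fold lower number from compound 1 to compound 3 (0.26 log units; within the scatter); together with a 1.9-fold lower number from compound 1 to compound 2 (0.29 log units; within the scatter), this means that neither exchange of cyclohexyl for an aryl group leaves the scatter. No other data bear on this result, and it can be reported only as a measured outcome.

From the compounds shown here alone, the shared core has so far carried only cyclohexyl, 4-methylphenyl and 4-bromophenyl on this nitrogen, so it remains open whether an amine or a carboxylic acid on the same aromatic carbon would give a step beyond the scatter. Going by these compounds, it also remains open whether a longer chain in place of the whole group on the nitrogen, or a different group in place of the nitro group on the shared core, would separate any compound from these three.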